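The source may hold more compounds than are shown below. What is called first, only, known or untested is meant among the compounds shown, and "the series" means these compounds.

In an assay on isolated protein for inhibition of 2-Hydroxyacid oxidase 2 (Rattus norvegicus) (on this read-out lower numbers stand for stronger inhibition and higher numbers for weaker inhibition), three compounds have been measured so far:
compound 1 `Cc1n[nH]c(C(=O)O)c1Cc1cccc(-c2ccccc2F)c1` gives 900 nM;
compound 2 `Cc1n[nH]c(C(=O)O)c1Cc1ccc(-c2ccc(OC(F)(F)F)cc2)cc1` gives 2000 nM;
compound 3 `Cc1n[nH]c(C(=O)O)c1Cc1ccc2ccccc2n1` gives 1700 nM.

Compound 1 has the lowest of the three numbers. Compound 3 lies within the scatter of compound 1, so no order between the two can be read; compound 2 stands beyond the scatter, above compound 1. Among the measured compounds shown here, no pair of measured compounds differs in a single place, so the next compound rests on the structural change alone. Compound 4 `Cc1n[nH]c(C(=O)O)c1Cc1cccc(C(N)=O)c1` differs from compound 1 in one place: carbamoyl in place of 2-fluorophenyl on an aromatic carbon. Compound 4 is expected to show a weaker number, a step of a 3.9-fold higher number from compound 1 to compound 4 (0.59 log units; beyond the scatter) of moderate size, beyond the scatter. For compound 4 the estimate in this assay is 3500 nM, with a range from 1000 nM to 12000 nM.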

Compound 4, half-maximal inhibitory concentration: 900 nM
The estimate for compound 4 lay 3.9-fold (0.59 log units) above the measured number; the measured number lies below the stated range.
By their numbers in this assay, from the lowest: compounds 1, 4, 3 and 2 (each within the scatter of the next, the first and the last beyond it).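

In this assay, carbamoyl in place of 2-fluorophenyl gives no change at the digits printed from compound 1 to compound 4 (within the scatter). At this position, therefore, the number holds without the six-membered aromatic ring of the 2-fluorophenyl group, and a group with no ring, carrying a hydrogen-bond donor and acceptor, reads the same. Nothing available explains why these two different groups read alike. The compounds shown leave open whether the amide hydrogens matter here, as a nitrile or a methyl ester at this position would test, and whether a bare hydrogen would hold the number too.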